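Replacing the 4-bromophenyl group of compound 2

The source may report more compounds than this note shows. Statements on the series, on what has been measured and on what is new or still open speak of the compounds shown alone.

compound 1 `CN(C)C(=O)c1cc2cnc(Nc3ccc(NC(=O)C4(C(=O)Nc5cccc(F)c5)CC4)cc3)nc2n1C1CCCC1`: 87%
compound 2 `CN(C)C(=O)c1cc2cnc(Nc3ccc(NC(=O)C4(C(=O)Nc5ccc(Br)cc5)CC4)cc3)nc2n1C1CCCC1`: 76.9%

In a functional assay on NCI-H1299 cells (Homo sapiens) for inhibition, read by CCK-8 assay, with a stated time of 72 h, tested at 10 uM (a lower number here means less inhibition of growth, a higher number more inhibition of growth at the concentration tested), compound 2 stands lower of the two measured compounds at 76.9%, while compound 1 gives 87%. The unmeasured compound 3 `CN(C)C(=O)c1cc2cnc(Nc3ccc(NC(=O)C4(C(=O)Nc5ccc(Cl)c(C(F)(F)F)c5)CC4)cc3)nc2n1C1CCCC1` differs from compound 2 at one place: 4-chloro-3-(trifluoromethyl)phenyl in place of 4-bromophenyl on an amide-type nitrogen. In words, it carries 4-chloro-3-(trifluoromethyl)phenyl in place of 4-bromophenyl on an amide-type nitrogen. Going by the values given here, only one measured step bears on this place, a number 10.1 percentage points lower from compound 1 to compound 2 (beyond the scatter), which is modest and beyond the scatter. That single step shows that a change here can move the read-out, but it involves a different pair of groups and fixes no direction for the new one. Only a small change is therefore expected, and the expected step is a number 3.1 percentage points higher from compound 2 to compound 3 (within the scatter), within the scatter. For compound 3 the estimated value is 80%, with an expected range of 64% to 93%.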

Compound 3, percent growth inhibition at one concentration: 90.4%
Compound 3: middle estimate off by 10.4 percentage points, on the low side; measured number inside the range.
By their numbers in this assay, from the lowest: compound 2; then compounds 1 and 3 (each within the scatter of the next).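

In this assay, this place on the amide-type nitrogen now shows movement in both directions, with a number 13.5 percentage points higher from compound 2 to compound 3 (beyond the scatter) as the first upward step. The larger 4-chloro-3-(trifluoromethyl)phenyl group, with its added heavy atoms, therefore does not lower the read-out here, and a number 3.4 percentage points higher from compound 1 to compound 3 (within the scatter) places it level with the 3-fluorophenyl group of compound 1. No measurement shown explains why these aryl groups differ.

The compounds shown leave open whether the chlorine or the trifluoromethyl group carries the rise, which a 4-chlorophenyl or a 3-(trifluoromethyl)phenyl group on the same nitrogen would help separate. They also leave open whether this place needs an aromatic ring at all, as a cyclohexyl group could test, and how a phenyl ring bearing an amine or a carboxylic acid would read.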